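The compounds below may be only part of what the source reports. "The series", "measured", "known", "first", "only" and "open" are said of these compounds alone.

Working notes on the series, cytotoxicity.

Two members have been measured in an ADME assay on HEL cells (Homo sapiens) for cytotoxicity; on this read-out lower numbers stand for higher toxicity in this test and higher numbers for lower toxicity in this test. Compound 1 `O=C(COc1cccc2ccccc12)N/N=C/c1ccccc1Br` gives in this assay only a limit, >= 20 ug/mL, and not a number. Compound 2 `C/C(=N\NC(=O)COc1cccc2ccccc12)c1ccccc1` gives in this assay a value of 20 ug/mL. Going by the values given here, compound 1 therefore stands at the limit of >= 20 ug/mL in this assay, at which 1 of the 2 values shown sits, so its true place is known only as a boundary; the two measured compounds sit at the same level, with no step between them beyond the scatter.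

Compound 3 `O=C(COc1cccc2ccccc12)N/N=C/c1cccc(Cl)c1` is still to be measured in this assay. It differs from compound 1 as follows: 3-chlorophenyl in place of 2-bromophenyl on a carbon with a double bond to nitrogen. Among the compounds with values here, no step between measured compounds covers a change of this kind, so nothing can be read off for its size. The step is expected to be none beyond the scatter, a number no higher from compound 1 to compound 3 (the limit leaves the size open), and a limit may again be reported. Compound 3 is thus estimated at 20 ug/mL, with the range 10 ug/mL to 40 ug/mL.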

Compound 3, minimum cytotoxic concentration: 100 ug/mL
Beside the measured number, compound 3's estimate is 5.0-fold (0.70 log units) below it; the whole stated range lies below it.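

Between compound 3 and compound 1 no step can be read in this assay: compound 1 gives only a limit, >= 20 ug/mL. The compounds shown leave open whether 3-chlorophenyl in place of 2-bromophenyl changes the read-out at all, and by how much.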